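The source may report more compounds than this note shows. Statements on the series, on what has been measured and on what is new or still open speak of the compounds shown alone.

Compound 1 `CCN1CCN(c2cc(C)c3cc(NC(=O)c4ccc[nH]4)ccc3n2)CC1` gives 13200 nM
Compound 2 `CCN1CCN(c2cc(C)c3cc(NC(=O)c4cccnc4)ccc3n2)CC1` gives 10600 nM
Compound 3 `CCN1CCN(c2cc(C)c3cc(NC(=O)c4ccc(Cl)cc4)ccc3n2)CC1` gives 3020 nM

In a functional assay on SK-BR-3 cells (Homo sapiens) for antiproliferative activity, read by MTT assay, with a stated time of 72 h (on this read-out lower numbers stand for stronger inhibition and higher numbers for weaker inhibition), compound 3 (3020 nM) has the lowest of the three numbers. Compound 4 `CCN1CCN(c2cc(C)c3cc(NC(=O)c4ccc5ccccc5n4)ccc3n2)CC1` carries quinolin-2-yl in place of 4-chlorophenyl on a carbonyl carbon. Three measured steps changed this same group. One (a 1.2-fold lower number from compound 1 to compound 2 (0.10 log units; within the scatter)) stays within the scatter. The other two (a 4.4-fold lower number from compound 1 to compound 3 (0.64 log units; beyond the scatter) and a 3.5-fold lower number from compound 2 to compound 3 (0.55 log units; beyond the scatter)) are modest, and both arrive at 4-chlorophenyl. Among the measured compounds shown here, no measured compound carries quinolin-2-yl, so these steps are only a rough guide. Still, a modest move to a higher number in this assay is expected, although a result within the scatter remains possible. The estimated step (a 2.0-fold higher number from compound 3 to compound 4 (0.30 log units; within the scatter)) reverses part of those gains. Compound 4 is expected at 6000 nM (2000 nM to 15000 nM) by this estimate.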

Compound 4, half-maximal inhibitory concentration: 3760 nM
The estimate for compound 4 lay 1.6-fold (0.20 log units) above the measured number, and the stated range covers the measured number.
By their numbers in this assay, from the lowest: compounds 3 and 4 (each within the scatter of the next); then compounds 2 and 1 (each within the scatter of the next).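

On this carbonyl carbon, quinolin-2-yl, with its two rings, does as well as the single ring of 4-chlorophenyl (a 1.2-fold higher number from compound 3 to compound 4 (0.10 log units; within the scatter)). It also keeps the advantage over the other two groups (a 2.8-fold lower number from compound 2 to compound 4 (0.45 log units; beyond the scatter); a 3.5-fold lower number from compound 1 to compound 4 (0.55 log units; beyond the scatter)), so chlorine is not required for the lower numbers, and a ring nitrogen alone does not set the higher ones, since compound 2 and compound 4 both carry one. Nothing available here explains these differences. Still open, going by these compounds, is how an amine or a carboxylic acid on the quinolin-2-yl ring would change the number.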